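The compounds below may be only part of what the source reports. "The series", "measured", "known", "first", "only" and "open" are said of these compounds alone.

Compound 1 `CCn1c(=O)c2nc(-c3ccc(S(=O)(=O)N4CCOCC4)cc3)[nH]c2n(CC)c1=O` gives 310 nM in an assay for binding affinity to adenosine receptor A1 (Rattus norvegicus), read by radioligand binding (a lower number here means a stronger inhibitor, a higher number a weaker inhibitor), the second highest of the three numbers at hand. Compound 2 `CCCn1c(=O)c2nc(-c3ccc(S(=O)(=O)NCCCC(=O)OCC)cc3)[nH]c2n(CCC)c1=O` gives 18.5 nM in this assay, a lower number beyond the scatter, while compound 3 `CCn1c(=O)c2nc(-c3cccc(S(=O)(=O)O)c3)[nH]c2n(CC)c1=O` gives 30700 nM, a higher number also beyond the scatter. Within the data shown here, no pair of measured compounds differs in one place only, so the move from compound 1 to compound 4 `CCn1c(=O)c2nc(-c3ccc(S(=O)(=O)NCCN(C)C)cc3)[nH]c2n(CC)c1=O` rests on the structural change alone: (2-(dimethylamino)ethyl)amino in place of morpholin-4-yl on a sulfonyl sulfur. Compound 2, with its lower number 18.5 nM and an open chain on its sulfonyl sulfur, is the only pointer, but it differs from compound 1 elsewhere as well. Compound 4 is therefore estimated at 150 nM, within a range from 40 nM to 600 nM. The expected step of a 2.1-fold lower number from compound 1 to compound 4 (0.32 log units; beyond the scatter) is a modest move toward a lower number, close to the edge of the scatter.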

Compound 4, half-maximal inhibitory concentration: 116 nM
Beside the measured number, compound 4's estimate is 1.3-fold (0.11 log units) above it; the range from low to high includes it.
By their numbers in this assay, from the lowest: compound 2; then compound 4; then compound 1; then compound 3.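

In this assay, the open-chain (2-(dimethylamino)ethyl)amino group on the sulfonyl sulfur gives a 2.7-fold lower number from compound 1 to compound 4 (0.43 log units; beyond the scatter), so this position does not depend on the morpholin-4-yl ring. The change removes a ring and adds a hydrogen-bond donor together, and this single pair cannot separate those two differences. No measurement given here accounts for the step. As far as these compounds go, what stays open is whether the dimethylamino group or the amino hydrogen matters more, a question that a piperazin-1-yl ring or a plain ethylamino chain on the same sulfur could help settle.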